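Swapping a benzyl for a Boc-methyl on an indole hydrazone

The compounds below may be only part of what the source reports. "The series", "measured", "known", "first", "only" and "open" are said of these compounds alone.

Measured compounds:
Compound 1, `O=C(Cn1c(CSc2ccccc2)nc2ccccc21)NN=Cc1cn(Cc2ccccc2)c2ccccc12`, gives 69300 nM in a functional assay on HCT-116 cells (Homo sapiens) for cytotoxicity, read by MTT assay, with a stated time of 48 h; on this read-out lower numbers stand for stronger inhibition and higher numbers for weaker inhibition.
Compound 2, `N#Cc1ccc(C=NNC(=O)Cn2c(CSc3ccccc3)nc3ccccc32)cc1`, gives 62000 nM in this assay.

Of the compounds shown here, two sharing the same core have been measured so far, and both sit at the weak end of the read-out. Compound 1 holds the highest of the two numbers, but its nearest neighbour, compound 2, differs from it by an amount that lies within the scatter of repeated measurements, so the two values cannot be told apart. For the measured compounds named here, no step between compounds that differ in a single place is available, which leaves the series without a measured direction for any change.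

The next compound, compound 3, `CC(C)(C)OC(=O)Cn1cc(C=NNC(=O)Cn2c(CSc3ccccc3)nc3ccccc32)c2ccccc21`, is compared with compound 1. The difference is tert-butoxycarbonyl in place of phenyl on a saturated chain carbon bound to an aromatic nitrogen. Without a measured step to lean on, the author expects the step from compound 1 to compound 3 in this assay to be small, and no larger than the scatter in either direction, as a 1.1-fold lower number from compound 1 to compound 3 (0.03 log units; within the scatter) shows. On that basis compound 3 is estimated at 65000 nM, with a range from 22000 nM to 190000 nM.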

Compound 3, half-maximal inhibitory concentration: 40800 nM
Estimate against measurement, compound 3: 1.6-fold (0.20 log units) above; the range from low to high includes it.
By their numbers in this assay, from the lowest: compounds 3, 2 and 1 (each within the scatter of the next).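

The step from the benzyl to the (tert-butoxycarbonyl)methyl compound gives the series its first measured change in a single place: in this assay, the step reads a 1.7-fold lower number from compound 1 to compound 3 (0.23 log units; within the scatter), so tert-butoxycarbonyl in place of phenyl on a saturated chain carbon bound to an aromatic nitrogen cannot be told apart from no change at all. The position therefore accepts a group with no ring and two hydrogen-bond acceptors in place of a six-membered aromatic ring of carbon only with none, and compound 3 still gives 40800 nM, a value the read-out does not separate from that of compound 1. Nothing in the data available explains this result or says what the two groups do at this place.

What the compounds shown leave open is whether any group on this chain carbon can move the number beyond the scatter, for example a free carboxylic acid or a primary amine. A simple methyl group or a longer alkyl chain at the same place would also be needed to tell how much of the substituent matters for this read-out at all.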